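Series notes: one side-chain change carried across two cores

This account rests on a few compounds, and the source may have more. Where it says the series, first, only, none or still open, it means among the compounds named here.

Compound 1 `Cc1cc(S(=O)(=O)/N=C(\N)N/N=C/C#Cc2ccccc2)c(SCc2ccccc2)cc1Cl` and compound 2 `C/C(C#Cc1ccccc1)=N\N/C(N)=N/S(=O)(=O)c1cc(C)c(Cl)cc1SCc1ccccc1` share a core and differ only at the chain on the amine nitrogen: a group of 11 heavy atoms (10 carbon, 1 nitrogen; one six-membered aromatic ring of carbon only) in place of a group of 10 heavy atoms (9 carbon, 1 nitrogen; one six-membered aromatic ring of carbon only), on an amine nitrogen. In an ADME assay on HaCaT cells (Homo sapiens) for cytotoxicity, read by MTT assay, with a stated time of 72 h (a higher number here means a weaker inhibitor, a lower number a stronger inhibitor), compound 1 gives 145000 nM and compound 2 gives 38000 nM, so the change brings a 3.8-fold lower number from compound 1 to compound 2 (0.58 log units; beyond the scatter).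

Compound 3 `Cc1cc(S(=O)(=O)/N=C(\N)N/N=C/C#Cc2ccccc2)c(SCc2ccc(C(F)(F)F)cc2)cc1Cl` carries a second core; relative to compound 1 the difference is trifluoromethyl in place of hydrogen on an aromatic carbon. In this assay compound 3 gives "not determined" (no result reported), so no number was obtained for it.

Compound 4 `C/C(C#Cc1ccccc1)=N\N/C(N)=N/S(=O)(=O)c1cc(C)c(Cl)cc1SCc1ccc(C(F)(F)F)cc1` stands to compound 3 as compound 2 stands to compound 1: a group of 11 heavy atoms (10 carbon, 1 nitrogen; one six-membered aromatic ring of carbon only) in place of a group of 10 heavy atoms (9 carbon, 1 nitrogen; one six-membered aromatic ring of carbon only), on an amine nitrogen. The surroundings of the place are described in identical words for both pairs, so this is the same change on a different core; it occurs twice among the four compounds.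

Compound 3 has no value, so the step to compound 4 cannot be anchored directly. Its size is nonetheless expected to resemble a 3.8-fold lower number from compound 1 to compound 2 (0.58 log units; beyond the scatter), a working assumption drawn from a single pair. Compound 4 is estimated near 30000 nM in this assay, within 8000 nM to 120000 nM. This rests on compound 2 at 38000 nM, with the core difference untested in this assay.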

Compound 4, half-maximal inhibitory concentration: 120000 nM
Compound 4: the middle estimate sits 4.0-fold (0.60 log units) below what was measured, within the range that was stated.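

In this assay, trifluoromethyl in place of hydrogen on an aromatic carbon gives a 3.2-fold higher number from compound 2 to compound 4 (0.50 log units; beyond the scatter), so the two cores do separate in this read-out when both carry the chain of 11 heavy atoms. The step from compound 3 to compound 4 cannot be read, as compound 3 has no number; the chain change therefore stands on one core only, as a 3.8-fold lower number from compound 1 to compound 2 (0.58 log units; beyond the scatter), and nothing here shows whether it keeps its size or even its direction on the second core. No measurement at hand bears on why the trifluoromethyl step comes out as it does.

Left open is whether the trifluoromethyl step would look the same with the chain of 10 heavy atoms, or with a longer chain on the amine nitrogen. Also open, on these data alone, is how a methoxy group or a carboxylic acid on that aromatic carbon would compare with trifluoromethyl and hydrogen.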